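The compounds below may be only part of what the source reports. "The series", "measured", "known", "first", "only" and "open" are said of these compounds alone.

In a functional assay on MCF7 cells (Homo sapiens) for inhibition, read by sulforhodamine B assay, with a stated time of 72 h (a higher number here means a weaker inhibitor, a lower number a stronger inhibitor), three compounds have been measured so far. Compound 1, `COc1cc(C(=O)/C=C/c2cn(-c3ccccc3)nc2-c2ccsc2)cc(OC)c1OC`, gives 4900 nM. Compound 2, `COc1ccc(C(=O)/C=C/c2cn(-c3ccccc3)nc2-c2ccsc2)c(OC)c1OC`, is built from the same atoms as compound 1, joined differently; how the two cores differ is not broken down here. In this assay compound 2 gives 7400 nM, a number within the scatter of compound 1. Compound 3, `COc1cc(C(=O)/C=C/c2cn(-c3ccccc3)nc2-c2cccnc2)cc(OC)c1OC`, is compound 1 with pyridin-3-yl in place of thiophen-3-yl on an aromatic carbon. In this assay compound 3 gives 14500 nM, and the step is a 3.0-fold higher number from compound 1 to compound 3 (0.47 log units; beyond the scatter), a modest but real weakening.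

Compound 4, `COc1ccc(C(=O)/C=C/c2cn(-c3ccccc3)nc2-c2cccnc2)c(OC)c1OC`, has not yet been measured in this assay. It is compound 2 with pyridin-3-yl in place of thiophen-3-yl on an aromatic carbon. Among the measured compounds shown here, this is the same kind of change as the one from compound 1 to compound 3, and the description of the place is identical word for word for both cores: on an aromatic carbon of a five-membered aromatic ring with two nitrogen atoms, next to the ring nitrogen and next to the ring atom bearing a large group. The change occurs twice among the compounds shown and has a measured outcome only once.

Because a 3.0-fold higher number from compound 1 to compound 3 (0.47 log units; beyond the scatter) lies beyond the scatter, a weakening of similar size is expected on the core of compound 2. The expected step is a 3.0-fold higher number from compound 2 to compound 4 (0.47 log units; beyond the scatter), resting on that single precedent. Compound 4 is therefore estimated at 22000 nM, with a likely range from 9000 nM to 55000 nM.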

Compound 4, half-maximal inhibitory concentration: 1400 nM
The estimate for compound 4 lay 16-fold (1.20 log units) above the measured number; the measured number lies below the stated range.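

In this assay, pyridin-3-yl in place of thiophen-3-yl on the core of compound 2 gives a 5.3-fold lower number from compound 2 to compound 4 (0.72 log units; beyond the scatter), so the change runs in the opposite direction to its earlier outcome on the core of compound 1. The two outcomes of this single change disagree, and the gap between them is real: the same change on two cores in this assay, a 3.0-fold higher number (0.47 log units; beyond the scatter) from compound 1 to compound 3 and a 5.3-fold lower number (0.72 log units; beyond the scatter) from compound 2 to compound 4, 16-fold (1.19 log units) apart, beyond the scatter of two such steps. This shows that in this series the result of the change on one core did not carry over to the other, even though the two cores are built from the same atoms joined differently; it does not show why they part ways, and with only two instances it cannot say which direction a further core would follow.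

The compounds shown leave open whether the two cores would also part ways with another group at this place on the five-membered ring, such as an amine or a carboxylic acid. They also leave open how the exchange of thiophen-3-yl for pyridin-3-yl would turn out on a third core built from the same atoms joined in yet another way.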